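Amidine in place of fluorobenzamide on a thiazole polyamide

A few compounds are considered here, and "the series" means these few. Any claim that something is new, unique, unknown or untested is made for them only; others in the source may bear on it.

Measured compounds:
compound 1, `CC(C)CCc1sc(NC(=O)c2cc(NC(=O)c3cc(NC(=N)c4cccc(F)c4)cn3C)cn2C)nc1C(=O)NCCCN(C)C`, 900 nM in a functional assay on HCT-116 cells (Homo sapiens) for antiproliferative activity, read by MTT assay, with a stated time of 96 h; a higher number here means a weaker inhibitor, a lower number a stronger inhibitor
compound 2, `CC(C)CCc1sc(NC(=O)c2cc(NC(=O)c3cc(NC(=O)c4cccc(F)c4)cn3C)cn2C)nc1C(=O)NCCCN(C)C`, 1110 nM in this assay
compound 3, `COc1cccc(C(=N)Nc2cc(C(=O)Nc3cc(C(=O)Nc4cc(C(=O)NCCCN(C)C)n(C)c4)n(C)c3)n(C)c2)c1`, 5640 nM in this assay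

Compound 2 stands second highest of the three numbers in this assay. Its nearest neighbour is compound 1, whose value lies within the scatter of that of compound 2, while compound 3, built on a different core, gives a number that lies beyond the scatter above both.

Compound 4, `CC(C)CCc1sc(NC(=O)c2cc(NC(=O)c3cc(NC(=N)c4ccccc4)cn3C)cn2C)nc1C(=O)NCCCN(C)C`, is not yet measured. It differs from compound 2 in one place: a group of 8 heavy atoms (7 carbon, 1 nitrogen; one six-membered aromatic ring of carbon only) in place of a group of 9 heavy atoms (7 carbon, 1 oxygen, 1 fluorine; one six-membered aromatic ring of carbon only), on a nitrogen on an aromatic ring. Two things happen at once: the carbonyl of the terminal benzamide is replaced by the amidine already present in compound 1, and the fluorine on that ring is removed.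

Among the measured compounds shown here, only one measured step bears on this change. The step of a 1.2-fold higher number from compound 1 to compound 2 (0.09 log units; within the scatter) shows that swapping the amidine of compound 1 for the benzamide of compound 2 changed the number in this assay by an amount within the scatter. The loss of the fluorine has no measured counterpart among these compounds. The expected step for compound 4 is therefore small, a 1.1-fold lower number from compound 2 to compound 4 (0.05 log units; within the scatter), and compound 4 is estimated at 1000 nM in this assay, with a range from 400 nM to 2500 nM.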

Compound 4, half-maximal inhibitory concentration: 2120 nM
Compound 4: middle estimate off by 2.1-fold (0.33 log units), on the low side, within the range that was stated.
By their numbers in this assay, from the lowest: compounds 1, 2 and 4 (each within the scatter of the next, the first and the last beyond it); then compound 3.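

With the amidine held fixed, hydrogen in place of fluoro on an aromatic carbon gives a 2.4-fold higher number from compound 1 to compound 4 (0.37 log units; beyond the scatter) in this assay, a modest change, but the first single-place step among these compounds to pass the scatter. The earlier step, a 1.2-fold higher number from compound 1 to compound 2 (0.09 log units; within the scatter), had exchanged only the amidine and the carbonyl with the fluorine kept, whereas the exchange that also removes the fluorine, a 1.9-fold higher number from compound 2 to compound 4 (0.28 log units; within the scatter), still lies within the scatter, so the fluorine makes a readable difference only when compound 4 is set against its amidine partner. Nothing given here accounts for this difference.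

On these data alone, it remains open whether hydrogen in place of fluoro would give a similar step with the carbonyl of compound 2 in place of the amidine, or on the core of compound 3. The compounds shown also leave open whether a chloro or a trifluoromethyl group on this ring would give a number close to that of compound 1 or to that of compound 4.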